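This account rests on a few compounds, and the source may have more. Where it says the series, first, only, none or still open, it means among the compounds named here.

Of the compounds shown here, three that share one core have so far been tested in an ADME assay on LLC-PK11 cells (Sus scrofa) for cytotoxicity, read by neutral red uptake, with a stated time of 48 h; a lower number here means a stronger inhibitor, a higher number a weaker inhibitor. Compound 1 `Cc1cc(NCCCCCCNc2ccnc3cc(Cl)ccc23)nc(N2CCN(C)CC2)n1` gives 7200 nM, the lowest of the three numbers. Compound 2 `Cc1cc(NCCCCNc2ccnc3cc(Cl)ccc23)nc(N2CCN(C)CC2)n1` gives 34600 nM, and compound 3 `Cc1cc(NCCCNc2ccnc3cc(Cl)ccc23)nc(N2CCN(C)CC2)n1` gives 34600 nM; these two show the same number, and each of them stands beyond the scatter above compound 1, so compound 1 is the strongest inhibitor of the three. Compound 2 and compound 3 differ from compound 1 in another part of the molecule, not in the part that is changed below, so they give no direct guide to the next step.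

Compound 4 `Cc1cc(NCCCCCCNc2ccnc3cc(Cl)ccc23)nc(N2CCCCC2)n1` has not yet been measured. Compared with compound 1 it carries piperidin-1-yl in place of 4-methylpiperazin-1-yl on an aromatic carbon. Among the compounds with values here, no measured pair shows the effect of this exact change, so the direction is uncertain. The expectation is a small shift at most, with a slightly higher number somewhat more likely than a lower one, and a step from compound 1 to compound 4 of a 1.4-fold higher number from compound 1 to compound 4 (0.14 log units; within the scatter) that may well stay within the scatter. The estimate for compound 4 in this assay is 10000 nM, with a range from 3000 nM to 30000 nM.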

Compound 4, half-maximal inhibitory concentration: 6300 nM
Compound 4: the middle estimate sits 1.6-fold (0.20 log units) above what was measured; the range from low to high includes it.
By their numbers in this assay, from the lowest: compounds 4 and 1 (each within the scatter of the next); then compounds 2 and 3 (each within the scatter of the next).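

In this assay, placing piperidin-1-yl instead of 4-methylpiperazin-1-yl on the aromatic carbon between two ring nitrogen atoms gives a 1.1-fold lower number from compound 1 to compound 4 (0.06 log units; within the scatter), so the two compounds cannot be told apart in this read-out. Within the data shown here, the exchange removes one ring nitrogen and one hydrogen-bond acceptor, yet the step stays within the normal variation of repeated measurements, which means this position tolerates this particular change in this assay, something the earlier compounds could not show. No supporting data are available to explain this result.

Among these compounds, a morpholine ring, an open-chain dimethylamino group or a small primary amine at the same position could still give a different number, so the tolerance seen here covers only this one pair. Among the compounds shown here, it also remains open whether the same exchange would give a similar result on the shorter chains of compound 2 and compound 3, since the only comparison here uses the chain of compound 1.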